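The source may report more compounds than this note shows. Statements on the series, on what has been measured and on what is new or still open speak of the compounds shown alone.

Three compounds in this series have a measured value, and one more is still awaiting its result.

Compound 1 `CCCNC(=O)C1CCN(C(=O)c2cc3[nH]cnc3n2Cc2ccc(OC)cc2)CC1` gives 1.27 h in an ADME assay on microsomes from liver (Homo sapiens) for metabolic stability; on this read-out lower numbers stand for a shorter-lived compound and higher numbers for a longer-lived compound. Compound 3 `CCCNC(=O)C1CC12CCN(C(=O)c1cc3sc(-c4ccccc4)nc3n1Cc1ccc(OC)cc1)CC2` gives 0.697 h in this assay. Compound 2 `CCCCC(=O)C1CCN(C(=O)c2cc3sccc3n2Cc2ccc(OC)cc2)CC1` gives 0.105 h in this assay, which is the lowest of the three numbers: compound 3 stands nearest to it, higher by an amount beyond the scatter, and compound 1 stands furthest from it, also beyond the scatter.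

Compound 4 `CCCNC(=O)C1CCN(C(=O)c2cc3sccc3n2Cc2ccc(OC)cc2)CC1` has not been measured. It differs from compound 2 in one place: propylamino in place of butyl on a carbonyl carbon. Both compound 1 and compound 3 carry the propylamino group on that carbonyl carbon, while compound 2 alone carries the butyl group there.

Because compound 1 gives 1.27 h and compound 3 gives 0.697 h, both well above the number of compound 2, an upward step is expected, of a size beyond the usual scatter, as estimated in a 5.2-fold higher number from compound 2 to compound 4 (0.72 log units; beyond the scatter). The change of core between compound 2 and the two other compounds means the comparison is not a clean one, so the estimate carries a wide range.

Compound 4 is expected to give 0.55 h in this assay, with a likely range from 0.2 h to 1.5 h.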

Compound 4, half-life: 0.177 h
For compound 4 the middle estimate is 3.1-fold (0.49 log units) above the measured one, and the stated range ends above it.
By their numbers in this assay, from the lowest: compounds 2 and 4 (each within the scatter of the next); then compounds 3 and 1 (each within the scatter of the next).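

In this assay, the exchange of butyl for propylamino on a carbonyl carbon gives a 1.7-fold higher number from compound 2 to compound 4 (0.23 log units; within the scatter), so on this core the two groups cannot be told apart by this read-out. For the compounds shown here, earlier, the position offered no matched pair: the propylamino group was seen only in compound 1 and compound 3, each with a different core, and its contribution could not be separated from the rest of the structure. Going by these compounds alone, this pair gives the first reading of the change on its own, and it shows that a swap of butyl for propylamino at this place, with the rest of the molecule held constant, leaves no effect that can be distinguished from the scatter; nothing available accounts for this result.

On these data alone, whether another group on that carbonyl carbon, such as a longer chain, a cyclic amine or a carboxylic acid, would give a step beyond the scatter remains open. Also open, as far as these compounds go, is whether the same exchange would read the same way on the core of compound 1 or compound 3.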